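This account rests on a few compounds, and the source may have more. Where it says the series, first, only, none or still open, it means among the compounds named here.

Compound 1 `O=C(CCCCC1CCSS1)NCc1cn(CCCOc2ccc3ccc(=O)oc3c2)nn1` gives 43.5% in a functional assay on PC-12 cells (Rattus norvegicus) for cytotoxicity, read by MTT assay, with stated times of 3 h and 2 h, tested at 50 uM; on this read-out lower numbers stand for a weaker effect and higher numbers for a stronger effect at the one concentration tested.
Compound 2 `CC(=O)c1cc2ccc(OCCCn3cc(CNC(=O)CCCCC4CCSS4)nn3)cc2oc1=O` gives 40.7% in this assay.
Compound 3 `O=C(CCCCC1CCSS1)NCc1cn(CCCCCOc2ccc3ccc(=O)oc3c2)nn1` gives 84.9% in this assay.

Compound 1 and compound 2 share a core and differ in one place, (acetyl in place of hydrogen on an aromatic carbon), and this change moved the read-out by a number 2.8 percentage points lower from compound 1 to compound 2 (within the scatter). Compound 4 `CC(=O)c1cc2ccc(OCCCCCn3cc(CNC(=O)CCCCC4CCSS4)nn3)cc2oc1=O` has not yet been measured; it differs from compound 3 by the same change in the same surroundings, (acetyl in place of hydrogen on an aromatic carbon). How the core of compound 3 differs from that of compound 1 is not broken down here. Because the same change gave a number 2.8 percentage points lower from compound 1 to compound 2 (within the scatter), the step from compound 3 to compound 4 is expected to be small as well, about a number 2.9 percentage points lower from compound 3 to compound 4 (within the scatter). Because compound 3 gave 84.9%, compound 4 is expected to give 82%, somewhere between 65% and 95%.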

Compound 4, a percentage reported as activity, at one concentration (the size of the read-out at that concentration, not a potency): 18.2%
For compound 4 the middle estimate is 63.8 percentage points above the measured one; measured number below the stated range.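

In this assay, acetyl in place of hydrogen on an aromatic carbon gave a number 66.7 percentage points lower from compound 3 to compound 4 (beyond the scatter), so a small step on one core did not predict the step on the other. The size of this change therefore depends on the core that carries it, at least in these two pairs: the same change on two cores in this assay, a number 2.8 percentage points lower (within the scatter) from compound 1 to compound 2 and a number 66.7 percentage points lower (beyond the scatter) from compound 3 to compound 4, 63.9 percentage points apart, beyond the scatter of two such steps

This does not show why the two cores respond so differently, and two pairs give no rule for any further core. As far as these compounds go, it remains open whether a different group on the same aromatic carbon, such as an amine or a carboxylic acid, would also give steps that differ between the core of compound 1 and the core of compound 3.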